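The compounds below may be only part of what the source reports. "The series", "measured", "known", "first", "only" and "open" are said of these compounds alone.

Measured in a functional assay on DU-145 cells (Homo sapiens) for inhibition, read by trypan blue exclusion, with a stated time of 96 h; on this read-out higher numbers stand for weaker inhibition of growth and lower numbers for stronger inhibition of growth:
compound 1, `COc1ccc(/C=C(/SCc2ccc(Cl)cc2)C(=O)c2ccc(C(=O)O)cc2)cc1`: 10000 nM
compound 2, `CSc1ccc(/C=C(/SCc2ccc(Cl)cc2)C(=O)c2ccc(C(=O)O)cc2)cc1`: > 100000 nM
compound 3, `CSc1ccc(/C=C(\C(=O)c2ccc(Br)cc2)S(=O)(=O)c2ccc(C)cc2)cc1`: 1000 nM

Among the compounds with values here, the value recorded for compound 2 is a limit of this assay and not a number; it is the one value that sits at the limit of > 100000 nM in this assay, at which 1 of the 3 values shown sits. Compound 2 and compound 1 differ in a single place: methoxy in place of methylsulfanyl on an aromatic carbon. This change gives an at least 10-fold lower number from compound 2 to compound 1 (1.00 log units; beyond the scatter), and since it starts from a limit only its lower bound is known. How the core of compound 3 differs from the core of compound 2 is not broken down here. Compound 4, `COc1ccc(/C=C(\C(=O)c2ccc(Br)cc2)S(=O)(=O)c2ccc(C)cc2)cc1`, has not yet been measured in this assay. It stands to compound 3 as compound 1 stands to compound 2: methoxy in place of methylsulfanyl on an aromatic carbon, at a place described in the same words, so the change is the same.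

On the strength of an at least 10-fold lower number from compound 2 to compound 1 (1.00 log units; beyond the scatter), a step in the same direction is expected here, though its size rests on one measured pair that begins at a limit. Compound 4 is expected to give 300 nM in this assay, most likely between 100 nM and 1500 nM. That estimate means an expected step of a 3.3-fold lower number from compound 3 to compound 4 (0.52 log units; beyond the scatter).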

Compound 4, concentration for 50% growth inhibition: 1000 nM
Compound 4: middle estimate off by 3.3-fold (0.52 log units), on the low side, and the stated range covers the measured number.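

In this assay, methoxy in place of methylsulfanyl on the core of compound 3 gives no change at the digits printed from compound 3 to compound 4 (within the scatter), so the clear gain seen on the other core does not appear here. Within this series, the change therefore cannot be carried from one core to the other with its size intact: the same change on two cores in this assay, an at least 10-fold lower number (1.00 log units; beyond the scatter) from compound 2 to compound 1 and no change at the digits printed (within the scatter) from compound 3 to compound 4, at least 10-fold (1.00 log units) apart, beyond the scatter of two such steps. The value of compound 2, > 100000 nM, is a limit and not a number, so the earlier step is known only by its lower bound, and with a single pair on each core the result shows that the outcome differed between these two cores but not which feature of them accounts for it.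

The compounds shown leave open which of the differences between the two cores matters, since those differences are not broken down into single changes. They also leave open what a longer chain such as ethoxy, or an amine such as dimethylamino, would give at the same place on either core.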